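Cytotoxicity from oxime to a sulfur-bearing side group

The compounds below may be only part of what the source reports. "The series", "measured", "known", "first", "only" and "open" are said of these compounds alone.

Measured in an ADME assay on Vero cells (Chlorocebus sabaeus) for cytotoxicity, read by MTT assay, with a stated time of 72 h; a higher number here means that more compound is tolerated, a lower number that less compound is tolerated:
Compound 1 `COc1c(N2C[C@H]3CCCN(C(=O)Cn4cc(CN5C(=O)C(=O)c6cccc(F)c65)nn4)[C@H]3C2)c(F)cc2c(=O)c(C(=O)O)cn(C3CC3)c12`: 32 ug/mL
Compound 2 `COc1c(N2C[C@H]3CCCN(C(=O)Cn4cc(CN5C(=O)/C(=N/O)c6ccccc65)nn4)[C@H]3C2)c(F)cc2c(=O)c(C(=O)O)cn(C3CC3)c12`: 32 ug/mL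

Compound 2 stands level with compound 1 on these numbers. Compound 3 `COc1c(N2C[C@H]3CCCN(C(=O)Cn4cc(CN5C(=O)/C(=N/NC(N)=S)c6ccccc65)nn4)[C@H]3C2)c(F)cc2c(=O)c(C(=O)O)cn(C3CC3)c12` keeps the rest of compound 2 but changes the hydroxy on a double-bonded nitrogen: a group of 4 heavy atoms (1 carbon, 2 nitrogen, 1 sulfur; no ring) in place of one oxygen atom, on a double-bonded nitrogen. Going by the values given here, the only measured step, no change at the digits printed from compound 1 to compound 2 (within the scatter), involves a different change, so it is a weak guide and no measured step covers this swap. No shift beyond the scatter is therefore expected in this assay, and the range is kept wide. The expected step is a 1.3-fold lower number from compound 2 to compound 3 (0.12 log units; within the scatter). For compound 3 the estimated value is 24 ug/mL. The expected range for compound 3 runs from 8 ug/mL to 64 ug/mL.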

Compound 3, half-maximal cytotoxic concentration: 16 ug/mL
The estimate for compound 3 lay 1.5-fold (0.18 log units) above the measured number; measured number inside the range.
By their numbers in this assay, from the lowest: compounds 3, 1 and 2 (each within the scatter of the next).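

In this assay, replacing the hydroxy on a double-bonded nitrogen with a sulfur-bearing group of 4 heavy atoms gives a 2.0-fold lower number from compound 2 to compound 3 (0.30 log units; within the scatter) and so this place takes the larger group without a shift beyond the scatter. Going by these compounds alone, the earlier step concerned a different place, so this is the first reading at this nitrogen. No measured evidence accounts for the step. The compounds shown leave open whether a methoxy group or an amine on this nitrogen would stay within the scatter of compound 2.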